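The compounds below may be only part of what the source reports. "The series", "measured", "known", "first", "only" and "open" are said of these compounds alone.

Measured so far, in an assay on isolated protein (Oryctolagus cuniculus) for inhibition of Calpain-2 catalytic subunit (Homo sapiens); on this read-out lower numbers stand for stronger inhibition and higher numbers for weaker inhibition:

compound 2 `CCNC(=O)C(=O)C(CC)NC(=O)C(CC(C)C)NC(=O)c1ccc2ccccc2n1` gives 300 nM
compound 1 `CCC(NC(=O)C(CC(C)C)NC(=O)OCc1ccccc1)C(=O)C(=O)NCc1ccc2ccccc2n1` gives 600 nM

Compound 2 has the lower of the two numbers, but the value of compound 1 lies within the scatter of repeated measurements, so the two compounds cannot be told apart on this read-out. Among the measured compounds shown here, the two structures differ in more than one place, so no single step links them.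

Compound 3 `CCNC(=O)C(=O)C(CC)NC(=O)C(CC(C)C)NC(=O)N1CCOCC1` differs from compound 2 in one place: morpholin-4-yl in place of quinolin-2-yl on a carbonyl carbon. The shared core, with its ethyl-amide end and the leucine-like side chain, stays as it is.

For the measured compounds named here, no measured pair shows what this kind of exchange does in this assay, so the expectation rests only on the values of compound 2 and compound 1. For compound 3 the expected value is 600 nM, with a range from 150 nM to 2500 nM, which would mean an estimated step of a 2.0-fold higher number from compound 2 to compound 3 (0.30 log units; within the scatter) in this assay.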

Compound 3, inhibition constant: 9900 nM
Compound 3: the middle estimate sits 17-fold (1.22 log units) below what was measured, outside the stated range (above it).
By their numbers in this assay, from the lowest: compounds 2 and 1 (each within the scatter of the next); then compound 3.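

In this assay the group on this carbonyl carbon matters a great deal: with the rest of the molecule unchanged, morpholin-4-yl in place of quinolin-2-yl gives a 33-fold higher number from compound 2 to compound 3 (1.52 log units; beyond the scatter) and thus a clear loss of inhibition. The earlier pair differed in more than one place and could not be told apart, so it gave no such sign for this position. Nothing available here explains why the step is so large.

The exchange replaces an aromatic two-ring group with a smaller non-aromatic ring that contains oxygen, and this single step cannot show which of those differences counts. A phenyl or piperidin-1-yl group on the same carbonyl carbon would help to separate them, but the compounds shown leave that question open.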